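The source may hold more compounds than are shown below. What is called first, only, known or untested is meant among the compounds shown, and "the series" means these compounds.

Compound 3 `C[C@@H]1CN(Cc2ccc(-c3ccccc3C(=O)N3CCC(Cc4ccc(F)cc4)CC3)cc2)C[C@H](C)N1` holds the second highest number of the three measured compounds in a functional assay on HEK293 cells for agonist activity at Motilin receptor (Homo sapiens), read by FLIPR; on this read-out higher numbers stand for an effect only at larger amounts of compound and lower numbers for an effect already at smaller amounts. Compound 3 gives 10 nM; compound 1 `C[C@@H]1CN(Cc2ccc(-c3ccccc3CN(C)C(=O)CSc3ccccc3)cc2)C[C@H](C)N1` gives 3.16 nM, and compound 2 `Cc1cc(CC(=O)N(C)Cc2ccccc2-c2ccc(CN3C[C@@H](C)N[C@@H](C)C3)cc2)on1` gives 1000 nM. Compound 4 `C[C@@H]1CN(Cc2ccc(-c3ccccc3C(=O)N3CCC(C(=O)c4ccc(F)cc4)CC3)cc2)C[C@H](C)N1` differs from compound 3 by (4-fluorophenyl)carbonyl in place of 4-fluorobenzyl on a saturated ring carbon. Going by the values given here, the only measured step, a 320-fold higher number from compound 1 to compound 2 (2.50 log units; beyond the scatter), concerns a different exchange at a different place and so does not bear directly on this change; no measured pair shows a carbonyl put in place of the saturated carbon linking the ring to the fluorinated ring. Without such a guide, the step expected in this assay is one within the scatter, a 1.5-fold higher number from compound 3 to compound 4 (0.18 log units; within the scatter). Compound 4 is therefore estimated at 15 nM, with a range from 4 nM to 60 nM.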

Compound 4, half-maximal effective concentration: 63.1 nM
Compound 4: middle estimate off by 4.2-fold (0.62 log units), on the low side; measured number above the stated range.
By their numbers in this assay, from the lowest: compound 1; then compound 3; then compound 4; then compound 2.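

In this assay, (4-fluorophenyl)carbonyl in place of 4-fluorobenzyl on a saturated ring carbon is a 6.3-fold higher number from compound 3 to compound 4 (0.80 log units; beyond the scatter). This first measured step at this place shows that the number responds, beyond the scatter, when a carbonyl replaces the saturated carbon linking the ring to the fluorinated ring. No evidence at hand accounts for this step.

The compounds shown leave open how an ether oxygen, a hydroxyl-bearing carbon or a longer chain would read at this link. They also leave open whether the step would persist without the fluorine.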